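Three Nitropyrimidines at the Limit, and a Fourth to Judge

A few compounds are considered here, and "the series" means these few. Any claim that something is new, unique, unknown or untested is made for them only; others in the source may bear on it.

Of the compounds shown here, three sharing one core have been tested in a functional assay on A549 cells (Homo sapiens) for antiproliferative activity, read by MTT assay, with a stated time of 48 h; on this read-out higher numbers stand for weaker inhibition and lower numbers for stronger inhibition. Compound 1 `COC(=O)CN(C)c1nc(Nc2ccccc2)ncc1[N+](=O)[O-]` is the smallest of them. In this assay compound 1 gives > 100000 nM, which is a limit of the assay rather than a number. Compound 2 `CCOC(=O)CN(Cc1ccccc1)c1nc(NCc2cccc(OC)c2)ncc1[N+](=O)[O-]` carries a larger set of groups. In this assay compound 2 gives > 100000 nM, again a limit and not a number. Compound 3 `COC(=O)CN(C)c1nc(Nc2cc(OC)c(OC)c(OC)c2)ncc1[N+](=O)[O-]` is the third. In this assay compound 3 gives > 100000 nM, once more a limit. So compound 2 stands exactly where the others do, at the limit of > 100000 nM in this assay, at which 3 of the 3 values shown sit, and no compound here can be called stronger or weaker than another.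

Compound 4 `CCOC(=O)CN(Cc1ccccc1)c1nc(Nc2cccc(OC)c2)ncc1[N+](=O)[O-]` differs from compound 2 in one place: 3-methoxyphenyl in place of 3-methoxybenzyl on a nitrogen on an aromatic ring. Among the measured compounds shown here, no measured pair shows this kind of change, so the size of its effect is unknown; with every value sitting at the limit, no step beyond the scatter is expected in this assay. Compound 4 is therefore estimated at 100000 nM, with a likely range from 30000 nM to 300000 nM. That estimate means an expected step of a number no higher from compound 2 to compound 4 (the limit leaves the size open).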

Compound 4, half-maximal inhibitory concentration: > 100000 nM
Compound 4 gave a limit, no number; the forecaster's own chance of this, stated with the estimate: 80%; the middle value lies on the limit itself.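

Compound 4, like compound 2, gives a limit and not a number, so swapping 3-methoxybenzyl for 3-methoxyphenyl yields no readable step between compound 2 and compound 4: the limit of > 100000 nM in this assay, at which 4 of the 4 values shown sit.

In this assay the compounds shown leave open how strongly any of them acts, and which change to the shared core would give a measurable number.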